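Adding a second chloro to the core: expected effect on cytotoxicity

The source may hold more compounds than are shown below. What is called first, only, known or untested is meant among the compounds shown, and "the series" means these compounds.

Measured compounds:
- compound 1 `ClCc1ccc(Cn2cnc3c(Cl)ncnc32)cc1`: 38900 nM
- compound 2 `ClCc1cccc(Cn2cnc3c(Cl)nc(Cl)nc32)c1`: 6450 nM

In a functional assay on EKVX cells (Homo sapiens) for cytotoxicity, read by sulforhodamine B assay, with a stated time of 48 h (a lower number here means that less compound is tolerated, a higher number that more compound is tolerated), compound 1 gives 38900 nM, the higher of the two numbers; compound 2 gives 6450 nM, and the gap between them is beyond the scatter. Compound 3 `ClCc1ccc(Cn2cnc3c(Cl)nc(Cl)nc32)cc1` is not yet measured. It differs from compound 1 by chloro in place of hydrogen on an aromatic carbon. For the measured compounds named here, no measured pair isolates this change, so its size is unknown. A move toward lower numbers is expected, because compound 2 gives 6450 nM. The step of a 4.3-fold lower number from compound 1 to compound 3 (0.64 log units; beyond the scatter) is an estimate. For compound 3 the expected value is 9000 nM, within 2500 nM to 30000 nM.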

Compound 3, concentration lethal to 50% of the cells: 58900 nM
Beside the measured number, compound 3's estimate is 6.5-fold (0.82 log units) below it; measured number outside the range, above it.
By their numbers in this assay, from the lowest: compound 2; then compounds 1 and 3 (each within the scatter of the next).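

In this assay putting chloro in place of hydrogen on an aromatic carbon, between two ring nitrogen atoms, changes the number by no more than the scatter (a 1.5-fold higher number from compound 1 to compound 3 (0.18 log units; within the scatter)). The added chloro alone therefore does not bring the lower number seen for compound 2 (6450 nM), which also has its chloromethyl group placed differently. No available evidence bears on this result. As far as these compounds go, whether an amine or a methoxy group at this same position would shift the number remains open, as does the effect of a longer chain in place of chloromethyl.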